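The compounds below may be only part of what the source reports. "The series", "measured", "known", "first", "only" and "open" are said of these compounds alone.

The measured compounds:

Compound 1 `CC(=O)Oc1cccc(N2C(=O)/C(=C/N3N=C(c4ccccc4)CC3c3ccccc3O)SC2=S)c1` gives in a functional assay on SK-OV-3 cells (Homo sapiens) for antiproliferative activity, read by MTT assay, with a stated time of 72 h (on this read-out lower numbers stand for stronger inhibition and higher numbers for weaker inhibition), the assay limit > 10000 nM.
Compound 2 `CC(=O)Oc1cccc(N2C(=O)/C(=C/N3N=C(c4ccccc4)CC3c3ccc(N(C)C)cc3)SC2=S)c1` gives in this assay the assay limit > 10000 nM.

Compound 2 therefore stands only at a limit, not at a number. Compound 3 `CN(C)c1ccc(C2CC(c3ccccc3)=NN2/C=C2\SC(=S)NC2=O)cc1` differs from it by hydrogen in place of 3-acetoxyphenyl on an amide-type nitrogen in a ring. Among the measured compounds shown here, the one measured step, a step that the two limits leave unreadable from compound 1 to compound 2, is unreadable because both ends sit at the limit of > 10000 nM in this assay, at which 2 of the 2 values shown sit. For the measured compounds named here, no step therefore shows how much the change toward compound 3 matters, and no direction can be read. Compound 3 is expected near 15000 nM, within 3000 nM to 60000 nM. The estimated step is a step that the limit leaves unreadable from compound 2 to compound 3.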

Compound 3, half-maximal inhibitory concentration: > 10000 nM
Compound 3: only a limit was reported; the forecaster's own chance of this, stated with the estimate: 65%; the middle value does not contradict the limit.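

Compound 2 and compound 3 both stand only at an assay limit, so the step between them cannot be read: the limit of > 10000 nM in this assay, at which 3 of the 3 values shown sit. On these data alone, whether the 3-acetoxyphenyl group or any other change in these compounds affects activity stays open.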